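This account rests on a few compounds, and the source may have more. Where it says the series, first, only, none or still open, it means among the compounds named here.

Measured so far:
- compound 1 `C/C=C/C=C/C(=O)N(Cc1ccc(OC)c(O)c1)c1cc(OC)c(OC)c(OC)c1` — 180 nM
- compound 2 `CC/C=C/C(=O)N(Cc1ccc(OC)c(O)c1)c1cc(OC)c(OC)c(OC)c1` — 63 nM
- compound 3 `COc1ccc(CN(C(=O)CN=[N+]=[N-])c2cc(OC)c(OC)c(OC)c2)cc1O` — 410 nM

Compound 3 stands at the top of the three numbers in a functional assay on HCT-116 cells (Homo sapiens) for inhibition, read by MTT assay, with a stated time of 48 h (on this read-out higher numbers stand for weaker inhibition and lower numbers for stronger inhibition), meaning it is the weakest inhibitor of the set: compound 1 sits nearer, compound 2 furthest away. Both measured steps that reach compound 3 go the same way: a 2.3-fold higher number from compound 1 to compound 3 (0.36 log units; beyond the scatter) and a 6.5-fold higher number from compound 2 to compound 3 (0.81 log units; beyond the scatter), so exchanging an unsaturated chain on the carbonyl carbon for azidomethyl raised the number each time.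

Compound 4 `COc1ccc(CN(C(=O)C(C)C)c2cc(OC)c(OC)c(OC)c2)cc1O` differs from compound 3 in one place: isopropyl in place of azidomethyl on a carbonyl carbon. Going by the values given here, the only comparable steps are those two, both modest, both pointing to azidomethyl as the weaker partner on this carbonyl carbon. Isopropyl is a saturated branch, unlike the chains of compound 1 and compound 2, so direct evidence is lacking; still, the expectation is a modest lowering of the number, a 2.7-fold lower number from compound 3 to compound 4 (0.44 log units; beyond the scatter), with a wide range because the new group is untested. Compound 4 is estimated at 150 nM, between 50 nM and 450 nM.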

Compound 4, half-maximal inhibitory concentration: 310 nM
For compound 4 the middle estimate is 2.1-fold (0.32 log units) below the measured one, and the stated range covers the measured number.
By their numbers in this assay, from the lowest: compound 2; then compounds 1, 4 and 3 (each within the scatter of the next, the first and the last beyond it).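

In this assay, exchanging azidomethyl for isopropyl on the carbonyl carbon gives a 1.3-fold lower number from compound 3 to compound 4 (0.12 log units; within the scatter) and so does not separate the two groups, although the step removes the 2 double bonds of azidomethyl and leaves the chain saturated and branched. Isopropyl also stands apart from but-1-en-1-yl, with a 4.9-fold higher number from compound 2 to compound 4 (0.69 log units; beyond the scatter) as the step, but not from penta-1,3-dien-1-yl, with a 1.7-fold higher number from compound 1 to compound 4 (0.24 log units; within the scatter) as the step, so among the four groups on this carbonyl carbon only the but-1-en-1-yl of compound 2 is separated from all the others. The data shown give no measured reason for this difference.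

On these data alone, whether the result for compound 2 depends on the double bond or on the chain length remains open, and a saturated butyl chain would address this. As far as these compounds go, the effect of an amine or a carboxylic acid on the chain at this carbonyl carbon also remains unknown.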